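The compounds below may be only part of what the source reports. "The series", "measured", "known", "first", "only" and "open" are said of these compounds alone.

Compound 1 `COc1ccc(/C=C2\CCC/C(=C\c3ccccc3Cl)C2=O)cc1OC`: 7100 nM
Compound 2 `COc1ccc(/C=C2\CCC/C(=C\c3cccc(Cl)c3)C2=O)cc1OC`: 5100 nM
Compound 3 `COc1ccc(/C=C2\CCC/C(=C\c3ccccc3Br)C2=O)cc1OC`: 5300 nM

In a functional assay on SW-620 cells (Homo sapiens) for cytotoxicity, read by MTT assay, with a stated time of 72 h (a higher number here means a weaker inhibitor, a lower number a stronger inhibitor), compound 3 gives 5300 nM, and the values do not separate it from the other two: a 1.3-fold lower number from compound 1 to compound 3 (0.13 log units; within the scatter), and a 1.0-fold higher number from compound 2 to compound 3 (0.02 log units; within the scatter). Compound 4 `COc1ccc(/C=C2\CCC/C(=C\c3ccc(Br)cc3)C2=O)cc1OC` carries 4-bromophenyl in place of 2-bromophenyl on a double-bonded chain carbon bound to a double-bonded ring carbon. For the measured compounds named here, no measured compound carries 4-bromophenyl. The closest evidence is the change from 2-chlorophenyl to 3-chlorophenyl, a 1.4-fold lower number from compound 1 to compound 2 (0.14 log units; within the scatter), which also stays within the scatter. No step beyond the scatter is therefore expected. In this assay the expected result is a 1.1-fold lower number from compound 3 to compound 4 (0.03 log units; within the scatter). Compound 4 is estimated at 5000 nM, with an expected range from 2500 nM to 10000 nM.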

Compound 4, half-maximal inhibitory concentration: 5200 nM
Compound 4: middle estimate off by 1.0-fold (0.02 log units), on the low side, within the range that was stated.
By their numbers in this assay, from the lowest: compounds 2, 4, 3 and 1 (each within the scatter of the next).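

In this assay, 4-bromophenyl in place of 2-bromophenyl stays within the scatter, with a 1.0-fold lower number from compound 3 to compound 4 (0.01 log units; within the scatter). The two chlorophenyl compounds give the same picture, with a 1.0-fold higher number from compound 2 to compound 4 (0.01 log units; within the scatter) and a 1.4-fold lower number from compound 1 to compound 4 (0.14 log units; within the scatter), so the four halogen-bearing phenyl groups at this place are not separated by these values. No measurement shown here offers an explanation for this. The compounds shown leave open whether a phenyl group carrying an amine or a carboxylic acid at this place would give a step beyond the scatter.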